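Shortening the Ester Arm: From Compound 3 to Compound 4

A few compounds are considered here, and "the series" means these few. Any claim that something is new, unique, unknown or untested is made for them only; others in the source may bear on it.

The measured compounds and their values in an ADME assay on the whole organism with Oryza sativa as the target, tested at 10 uM; on this read-out higher numbers stand for a weaker effect at the one concentration tested and lower numbers for a stronger effect:
Compound 1 `CCCCc1ccc(NC(=O)N[C@@H](C)c2ccccc2)cc1`: 60%
Compound 2 `CCCCCCc1ccc(NC(=O)N[C@@H](C)c2ccccc2)cc1`: 99%
Compound 3 `CCOC(=O)c1ccc(NC(=O)N[C@@H](C)c2ccccc2)cc1`: 92%

All three share one core and differ only in the group on the aromatic carbon. Compound 3 stands second highest of the three numbers in this assay; its nearest neighbour is compound 2, which sits a number 7 percentage points lower from compound 2 to compound 3 (within the scatter), so the two are not distinguishable, while compound 1 lies well apart, as shown by a number 32 percentage points higher from compound 1 to compound 3 (beyond the scatter).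

Compound 4 `CC(=O)c1ccc(NC(=O)N[C@@H](C)c2ccccc2)cc1` is the next compound, not yet measured. Compared with compound 3 the difference is methyl in place of ethoxy on a carbonyl carbon.

Neither measured step touches this carbonyl carbon: the two steps into compound 3 from compound 1 and from compound 2 replace a chain on the aromatic carbon, not the ethoxy group. Among the measured compounds shown here, they show only that compound 3 sits with compound 2 near the top of the range. For the measured compounds named here, with no step of the same kind to lean on, the expected change in this assay is none beyond the scatter, so compound 4 is expected to give about 88%, within 65% to 100%, meaning an estimated step of a number 4 percentage points lower from compound 3 to compound 4 (within the scatter).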

Compound 4, a percentage reported as activity, at one concentration (the size of the read-out at that concentration, not a potency): 96%
The estimate for compound 4 lay 8 percentage points below the measured number, and the stated range covers the measured number.
By their numbers in this assay, from the lowest: compound 1; then compounds 3, 4 and 2 (each within the scatter of the next).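

On this carbonyl carbon, exchanging ethoxy for the smaller methyl, which also takes away the hydrogen-bond acceptor counted on the ethoxy group, leaves this assay without a change beyond the scatter: a number 4 percentage points higher from compound 3 to compound 4 (within the scatter). Acetyl on the aromatic carbon also cannot be told apart from hexyl, a number 3 percentage points lower from compound 2 to compound 4 (within the scatter), yet it stands well apart from butyl, a number 36 percentage points higher from compound 1 to compound 4 (beyond the scatter), so among these four compounds only compound 1 lies apart from the rest. Nothing available explains why the ethoxy-to-methyl exchange leaves the read-out within the scatter or why compound 1 stands apart.

The two groups compared on this carbonyl carbon, ethoxy and methyl, say nothing about how an amine or a hydroxy group would behave there, which would turn the ester into an amide or a carboxylic acid. On the aromatic carbon, a pentyl chain would show how the read-out runs between butyl and hexyl, and a shorter chain such as ethyl would show whether the lower number of compound 1 extends below butyl.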